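Compound 3 to compound 4: exchanging the group on nitrogen

This account rests on a few compounds, and the source may have more. Where it says the series, first, only, none or still open, it means among the compounds named here.

Compound 1 `O=C(Nc1cc(Nc2ccc(Cl)cc2)ncn1)c1ccc(F)cc1` gives 18600 nM
Compound 2 `CCOC(=O)CCCC(=O)Nc1cc(Nc2cccc(Cl)c2)ncn1` gives 21100 nM
Compound 3 `O=C(O)CCC(=O)Nc1cc(Nc2ccc(Cl)cc2)ncn1` gives 19000 nM

In an ADME assay on BEAS-2B cells (Homo sapiens) for cytotoxicity, read by MTT assay, with a stated time of 72 h (on this read-out lower numbers stand for stronger inhibition and higher numbers for weaker inhibition), compound 3 gives 19000 nM and lies within the scatter of both other compounds, so these three numbers set up no order among them. Compound 4 `Clc1ccc(Nc2cc(Nc3cccc(Cl)n3)ncn2)cc1` has yet to be measured. Its difference from compound 3 is counted as 6-chloropyridin-2-yl in place of (2-carboxyethyl)carbonyl on a nitrogen on an aromatic ring and amounts to 6-chloropyridin-2-yl in place of (2-carboxyethyl)carbonyl on a nitrogen on an aromatic ring.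

Among the compounds with values here, only one measured step bears on this change: a 1.0-fold higher number from compound 1 to compound 3 (0.01 log units; within the scatter) stays within the scatter. That step exchanges one group on a carbonyl carbon for another, and both of its compounds keep the carbonyl, which compound 4 does not have. Within the data shown here, no measured compound carries a 6-chloropyridin-2-yl group, so this guidance is limited. No step beyond the scatter is therefore expected in this assay, and the estimated change is a 1.2-fold lower number from compound 3 to compound 4 (0.07 log units; within the scatter) with a wide margin on either side. For compound 4 the estimated value is 16000 nM, with an expected range from 6000 nM to 42000 nM.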

Compound 4, half-maximal inhibitory concentration: 18100 nM
Beside the measured number, compound 4's estimate is 1.1-fold (0.05 log units) below it, and the stated range covers the measured number.
By their numbers in this assay, from the lowest: compounds 4, 1, 3 and 2 (each within the scatter of the next).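

In this assay, the step of a 1.0-fold lower number from compound 3 to compound 4 (0.02 log units; within the scatter) stays within the scatter, and it is the first step shown that removes the carbonyl from the nitrogen on an aromatic ring rather than exchanging the group carried on that carbonyl. The earlier step, a 1.0-fold higher number from compound 1 to compound 3 (0.01 log units; within the scatter), had kept the carbonyl in both compounds, so it could not show whether the read-out depended on that atom group; here the (2-carboxyethyl)carbonyl, with its carboxylic acid, gives way to 6-chloropyridin-2-yl, a six-membered aromatic ring, and the number shows no measurable shift. No evidence is available to explain why this exchange leaves the read-out within the scatter.

Neither step shown goes beyond the scatter, so it remains open whether any group at this place can move the number at all in this assay. An aliphatic amine, a longer chain ending in a carboxylic acid, or a pyridin-2-yl without its chlorine on this nitrogen would each test that question, and the compounds shown say nothing about any of them.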